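The source may hold more compounds than are shown below. What is called first, only, known or untested is meant among the compounds shown, and "the series" means these compounds.

Measured so far in an in vitro assay on P815B cells for inhibition of Indoleamine 2,3-dioxygenase 1 (Mus musculus), tested at 20 uM; on this read-out lower numbers stand for less inhibition and higher numbers for more inhibition at the one concentration tested (going by the name of the read-out):
- compound 1, `O=C(Cc1cccnc1)c1cc2cc(-c3ccccc3)ccc2[nH]1`: "not active" (no number reported) (no number given)
- compound 2, `O=C(Cc1cccnc1)c1cc2cc(Br)ccc2[nH]1`: "not active" (no number reported) (no number given)
- compound 3, `Cc1ccc2[nH]c(C(=O)Cc3cccnc3)cc2c1`: 21%

Going by the values given here, compound 3 is the only member of the set with a number attached; compounds 1 and 2 were reported as not active in this assay without a value, so nothing can be said about the size of any gap between them and compound 3. Within what is shown, compound 3 stands alone as the single quantified entry, and its reading is modest.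

Compound 4, `O=C(Cc1cccnc1)c1cc2cc(OC(F)(F)F)ccc2[nH]1`, has not yet been measured. It differs from compound 3 in one place: trifluoromethoxy in place of methyl on an aromatic carbon. Among the compounds with values here, no pair of measured compounds in the set is separated by a single change of this kind, so there is no step to lean on. Two other groups placed on the same part of the core, the phenyl of compound 1 and the bromine of compound 2, gave no reportable activity, which points to a change at this position tending toward less inhibition rather than more.

Taking that into account, the expected step from compound 3 to compound 4 is a number 7 percentage points lower from compound 3 to compound 4 (within the scatter), that is, at most a small fall, within or just beyond the usual scatter. For compound 4 in this assay the estimate is 14%, with a range from 0% to 32%.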

Compound 4, a percentage reported as inhibition, at one concentration (the size of the read-out at that concentration, not a potency): 12%
The estimate for compound 4 lay 2 percentage points above the measured number; the measured number falls inside the stated range.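

In this assay trifluoromethoxy in place of methyl on an aromatic carbon gives a number 9 percentage points lower from compound 3 to compound 4 (within the scatter) and so no change that can be told from the scatter. Compound 1 and compound 2 carry no number, whereas compound 4 does, so replacing methyl at this position does not always end in a report of no activity. No measurement here explains the readings of these compounds.

From the compounds shown here alone, whether any group at this position can raise inhibition well beyond these modest readings remains open, as does the reading of the shared core with only hydrogen there. An amine, a carboxylic acid or a methoxy group at this position would show whether the outcome depends on the kind of group placed there.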